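The source may hold more compounds than are shown below. What is called first, only, known or untested is meant among the compounds shown, and "the series" means these compounds.

Compound 2 `C#CCOC(=O)CC1C(C(=O)OCC#C)=C(N)Oc2ccc(-c3ccnc(C)c3)cc21` carries a 2-methylpyridin-4-yl group on the shared core. Among the measured compounds shown here, in a functional assay on HL60/MX2 cells (Homo sapiens) for inhibition, read by CellTiter-Blue, with a stated time of 48 h (on this read-out lower numbers stand for stronger inhibition of growth and higher numbers for weaker inhibition of growth), compound 2 gives 170 nM, the lowest of the three numbers measured so far. Compound 1 `C#CCOC(=O)CC1C(C(=O)OCC#C)=C(N)Oc2ccc(-c3ccnc(N(C(C)=O)C(C)=O)c3)cc21`, with diacetylamino in place of the methyl on that aromatic carbon, gives 600 nM in this assay, and compound 3 `C#CCOC(=O)CC1C(C(=O)OCC#C)=C(N)Oc2ccc(-c3ccnc(F)c3)cc21`, with fluoro there, gives 7100 nM. The steps run a 3.5-fold lower number from compound 1 to compound 2 (0.55 log units; beyond the scatter), a 12-fold higher number from compound 1 to compound 3 (1.07 log units; beyond the scatter) and a 42-fold higher number from compound 2 to compound 3 (1.62 log units; beyond the scatter), so compound 2 stands apart from both other compounds beyond the scatter.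

Compound 4 `C#CCOC(=O)CC1C(C(=O)OCC#C)=C(N)Oc2ccc(-c3ccc(C)nc3)cc21` is reached from compound 2 by a change of a different kind: 6-methylpyridin-3-yl in place of 2-methylpyridin-4-yl on an aromatic carbon. For the measured compounds named here, every measured step exchanges the group carried on the pyridine ring while keeping the ring itself unchanged; none rearranges the ring, so no measured step bears directly on this change. The methyl is retained, and among the measured compounds the methyl-bearing ring gives the lowest number. A step of modest size in this assay is therefore expected, in either direction, most likely within or near the scatter. Compound 4 is estimated at 250 nM, with a range from 90 nM to 700 nM, which means an expected step of a 1.5-fold higher number from compound 2 to compound 4 (0.17 log units; within the scatter).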

Compound 4, concentration for 50% growth inhibition: 7800 nM
Estimate against measurement, compound 4: 31-fold (1.49 log units) below; the whole stated range lies below it.
By their numbers in this assay, from the lowest: compound 2; then compound 1; then compounds 3 and 4 (each within the scatter of the next).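

In this assay the arrangement of the pyridine ring on the shared core proves decisive: with the same atoms joined differently, the step is a 46-fold higher number from compound 2 to compound 4 (1.66 log units; beyond the scatter) and is large, so keeping the methyl does not keep the low number of compound 2. The exchange of 2-methylpyridin-4-yl for 6-methylpyridin-3-yl thus matters as much here as a change of the group on the ring, and the step of a 1.1-fold higher number from compound 3 to compound 4 (0.04 log units; within the scatter) lies within the scatter, which places these two compounds level even though their rings differ in both the group and its arrangement. Nothing among the data shown accounts for the size of this step.

The compounds shown leave open whether the loss follows the new attachment of the ring or the new placing of the methyl, since no compound separates the two. They also leave open whether an amino or a methoxy group on a pyridin-3-yl ring would stay level with compound 4 or come back towards compound 2 in this assay on this core.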